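Removing the methyl from the aryl ring of compound 3

The source may report more compounds than this note shows. Statements on the series, on what has been measured and on what is new or still open speak of the compounds shown alone.

Compound 3 `Cc1ccccc1-n1cc(CSc2nc3ccccc3s2)nn1` stands second highest among the three compounds measured in a functional assay on the whole organism (strain Albino Wistar) for inhibition, with Rattus norvegicus as the target, read by paw edema, with stated times of 1 h and 5 h, at a dose of 10 mg/kg by the oral route (a lower number here means less inhibition, a higher number more inhibition at the dose given (going by the name of the read-out)), where compound 3 gives 43.4%. Its nearest neighbour is compound 1 `Clc1cccc(-n2cc(CSc3nc4ccccc4s3)nn2)c1`, which in this assay gives 39.6%; the step of a number 3.8 percentage points higher from compound 1 to compound 3 (within the scatter) lies within the scatter. Furthest from it is compound 2 `O=[N+]([O-])c1ccc(-n2cc(CSc3nc4ccccc4s3)nn2)cc1`, which in this assay gives 65.5%, a number that sits beyond the scatter above compound 3.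

Compound 4 `c1ccc(-n2cc(CSc3nc4ccccc4s3)nn2)cc1` has not yet been measured. It differs from compound 3 by hydrogen in place of methyl on an aromatic carbon. For the measured compounds named here, no measured step removes a methyl, so the comparison is indirect: the one step among the measured compounds that changes the group on the aromatic nitrogen, a number 3.8 percentage points higher from compound 1 to compound 3 (within the scatter), stays within the scatter, while compound 2 shows that a different group on that ring can move the number well beyond it. A change as small as methyl to hydrogen on the ring of compound 3 is therefore expected to give no step beyond the scatter, a number 2.4 percentage points lower from compound 3 to compound 4 (within the scatter). Compound 4 is estimated to reach 41% in this assay, between 28% and 55%.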

Compound 4, a percentage reported as inhibition, in the whole organism at one dose (the size of the read-out at that dose, not a potency): 32.1%
The estimate for compound 4 lay 8.9 percentage points above the measured number; measured number inside the range.
By their numbers in this assay, from the lowest: compounds 4, 1 and 3 (each within the scatter of the next, the first and the last beyond it); then compound 2.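

In this assay, compound 4 supplies the unsubstituted phenyl ring as a reference, and it shows that even a single methyl on an aromatic carbon, ortho to a large group, can matter: going from 2-methylphenyl to phenyl gives a number 11.3 percentage points lower from compound 3 to compound 4 (beyond the scatter), a modest step. Against the same reference the three groups do not count equally, as removing chloro gives a number 7.5 percentage points lower from compound 1 to compound 4 (within the scatter), a change that cannot be told apart from repeat scatter, while removing nitro gives a number 33.4 percentage points lower from compound 2 to compound 4 (beyond the scatter), a large step that marks nitro as the one substituent here far removed from the plain ring. No measurement among the data shown accounts for either the methyl step or the nitro step.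

The compounds shown leave open whether the large step belongs to the nitro group itself or to where it sits on the ring, as methyl, chloro and nitro each occupy a different place. They also leave open how an amine or a carboxylic acid on this ring would compare with the plain phenyl of compound 4.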